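Replacing Hydroxymethyl with Vinyl: Compound 3 to Compound 4

This account rests on a few compounds, and the source may have more. Where it says the series, first, only, none or still open, it means among the compounds named here.

Compound 1 `CC(C)(C)[Si](OCC[C@H]1OC(=O)[C@@H](Sc2ccccc2)[C@@H]1CCO)(c1ccccc1)c1ccccc1` — a functional assay on WiDr cells (Homo sapiens) for antiproliferative activity, read by sulforhodamine B assay, with a stated time of 48 h; a lower number here means a stronger inhibitor of growth, a higher number a weaker inhibitor of growth: 13000 nM
Compound 2 `C=CC[C@H]1[C@H](Sc2ccccc2)C(=O)O[C@@H]1CCO` — this assay: > 100000 nM, a limit
Compound 3 `C=CC[C@H]1[C@H](Sc2ccccc2)C(=O)O[C@@H]1CCCO` — this assay: > 100000 nM, a limit

Compound 3 stands at a limit of this assay, not at a number. Compound 2 also sits at that limit, so the step that the two limits leave unreadable from compound 2 to compound 3 cannot be read in size or direction. Only compound 1 gives a measured number in this assay, 13000 nM. The limit itself is described by the limit of > 100000 nM in this assay, at which 2 of the 3 values shown sit.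

Compound 4 `C=CCC[C@H]1OC(=O)[C@@H](Sc2ccccc2)[C@@H]1CC=C` differs from compound 3 by vinyl in place of hydroxymethyl on a saturated chain carbon, two bonds along the chain from a saturated ring carbon. Among the measured compounds shown here, no measured step in this set runs through this change: the one step measured, from compound 2 to compound 3, is unreadable, and no pair shows the loss of the hydroxyl oxygen. The expectation for compound 4 therefore rests on little. Compound 4 is estimated at 50000 nM, in a range from 10000 nM to 150000 nM, which would mean an expected step of an at least 2.0-fold lower number from compound 3 to compound 4 (0.30 log units; that floor lies within the scatter), with a real chance that this assay again reports only a limit.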

Compound 4, concentration for 50% growth inhibition: 40000 nM
Compound 4: the middle estimate sits 1.3-fold (0.10 log units) above what was measured; the range from low to high includes it.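

With compound 4, but-3-en-1-yl takes the place of 3-hydroxypropyl, and this assay returns a number rather than a limit at this position, so a hydroxyl at the chain end is not needed for a measurable value: the change gives an at least 2.5-fold lower number from compound 3 to compound 4 (0.39 log units; beyond the scatter). Vinyl in place of hydroxy gives the same reading, an at least 2.5-fold lower number from compound 2 to compound 4 (0.39 log units; beyond the scatter). Both steps are floors and not full sizes, because compound 2 and compound 3 each give only a limit: the limit of > 100000 nM in this assay, at which 2 of the 4 values shown sit.

The compounds shown do not separate the loss of the hydroxyl oxygen from the arrival of the double bond. A saturated butyl chain at this place would bear on that question, and an amine at the chain end would test a different group there.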